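This account rests on a few compounds, and the source may have more. Where it says the series, first, only, none or still open, it means among the compounds named here.

Measured compounds and their values in the cytotoxicity read-out:

compound 1 `CC(=O)OCCOCN1C(=O)c2ccccc2NS1(=O)=O`: > 50 ug/mL
compound 2 `CC(=O)OCCOCN1c2ccccc2C(=O)N(Cc2ccccc2)S1(=O)=O`: 50 ug/mL
compound 3 `C#CCOCN1c2ccccc2C(=O)N(Cc2ccccc2)S1(=O)=O`: 50 ug/mL

The read-out is a functional assay on HEL cells (Homo sapiens) for cytotoxicity; a higher number here means that more compound is tolerated, a lower number that less compound is tolerated. For compound 1 the value > 50 ug/mL is a limit of the assay, not a number. This is the limit of > 50 ug/mL in this assay, at which 1 of the 3 values shown sits. Compound 2 gives 50 ug/mL and compound 3 gives 50 ug/mL in this assay.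

Compound 2 and compound 3 are joined by one structural change, (ethynyl in place of acetoxymethyl on a saturated chain carbon bound to an oxygen on a saturated carbon). The step that this change made is no change at the digits printed from compound 2 to compound 3 (within the scatter), so the two values sit within the scatter of each other and no order between them is claimed.

Compound 1 and compound 2 share no single counted difference; the difference between the two cores is not broken down here.

The unmeasured compound is compound 4 `C#CCOCN1C(=O)c2ccccc2NS1(=O)=O`. It stands to compound 1 as compound 3 stands to compound 2: the change is ethynyl in place of acetoxymethyl on a saturated chain carbon bound to an oxygen on a saturated carbon. The place lines of the two changes read the same, so this is the same change made on the core of compound 1 instead of the core of compound 2.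

From compound 1 to compound 4 the expected step in this assay is a step that the limit leaves unreadable from compound 1 to compound 4, resting on the measured step of no change at the digits printed from compound 2 to compound 3 (within the scatter) between compound 2 and compound 3, which left the value unchanged within the scatter. Since compound 1 sits at a limit, compound 4 is also expected to sit at or near that limit rather than to give a number. Compound 4 is thus estimated at 60 ug/mL, with a range from 35 ug/mL to 120 ug/mL.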

Compound 4, minimum cytotoxic concentration: > 50 ug/mL
Compound 4 ended at the assay's limit; the forecaster's own chance of this, stated with the estimate: 70%; the middle value lies beyond the limit too.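

In this assay compound 4 gives > 50 ug/mL, a limit of the assay and not a number. Compound 1 gives > 50 ug/mL, also a limit. Among these compounds, no step between compound 1 and compound 4 can be read, because both values sit at the limit: the limit of > 50 ug/mL in this assay, at which 2 of the 4 values shown sit. Left open is whether ethynyl in place of acetoxymethyl changes the tolerated concentration on the core of compound 1 at all.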